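This account rests on a few compounds, and the source may have more. Where it says the series, first, only, none or still open, it means among the compounds named here.

Within the data shown here, in a functional assay on A549 cells (Homo sapiens) for antiproliferative activity, read by MTT assay (a higher number here means a weaker inhibitor, a lower number a stronger inhibitor), compound 3 (`CC1(C)CCc2c(ccc(C(=O)/C=C/c3ccc(OCc4cn(-c5ccc(Cl)cc5)nn4)cc3)c2O)O1`) is recorded as "not active" (no number reported), with no number, so no step can be counted from it. Compound 4 (`CCc1ccccc1-n1cc(COc2ccc(/C=C/C(=O)c3ccc4c(c3O)CCC(C)(C)O4)cc2)nn1`) keeps the core of compound 3 and changes one group: 2-ethylphenyl in place of 4-chlorophenyl on an aromatic nitrogen. Among the measured compounds shown here, the only measured step runs from compound 1 (`Cc1c(-n2cc(COc3ccc(/C=C/C(=O)c4cc5c(cc4O)OC(C)(C)CC5)cc3)nn2)cccc1[N+](=O)[O-]`), at 65900 nM, to compound 2 (`CCc1ccccc1-n1cc(COc2ccc(/C=C/C(=O)c3cc4c(cc3O)OC(C)(C)CC4)cc2)nn1`), at 137000 nM, which carries 2-ethylphenyl on a different core. That step, a 2.1-fold higher number from compound 1 to compound 2 (0.32 log units; beyond the scatter), is modest and gives only a rough guide. No step size can be set, but a weak reading near compound 2 or another result without a number is expected. Compound 4 is estimated at 120000 nM, with an expected range of 50000 nM to 300000 nM.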

Compound 4, half-maximal inhibitory concentration: 112000 nM
Estimate against measurement, compound 4: 1.1-fold (0.03 log units) above; the range from low to high includes it.
By their numbers in this assay, from the lowest: compounds 1, 4 and 2 (each within the scatter of the next, the first and the last beyond it).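

In this assay compound 3 is recorded as "not active" (no number reported) and compound 4 gives 112000 nM, so no step can be read between them. The compounds shown leave open how 2-ethylphenyl and 4-chlorophenyl compare in this series. Nothing here offers an explanation for these results.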